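This account rests on a few compounds, and the source may have more. Where it says the series, first, only, none or still open, it means among the compounds named here.

In a functional assay on HCT-116 cells (Homo sapiens) for inhibition, read by CCK-8 assay, with a stated time of 72 h (on this read-out lower numbers stand for stronger inhibition and higher numbers for weaker inhibition), two compounds have been measured so far. Compound 1 (`Nc1ccccc1NC(=O)c1ccc(CNC(=O)c2n[nH]cc2NC(=O)c2ccccc2Cl)cc1`) gives 900 nM, and compound 2 (`O=C(NO)c1ccc(CNC(=O)c2n[nH]cc2NC(=O)c2ccccc2F)cc1`) gives 2200 nM. Compound 2 therefore has the higher of the two numbers, and its gap to compound 1 lies beyond the usual scatter. Compound 3 (`O=C(NO)c1ccc(CNC(=O)c2n[nH]cc2NC(=O)c2ccccc2Cl)cc1`) has yet to be measured in this assay. It differs from compound 2 in one place, with chloro in place of fluoro on an aromatic carbon, ortho to a large group: chloro in place of fluoro on an aromatic carbon. Among the compounds with values here, no measured pair shows this change alone, so the data give no direct guide to its size. Only a small step is expected, probably none beyond the scatter, with a slight lean towards a lower number. The expected change is a 1.2-fold lower number from compound 2 to compound 3 (0.09 log units; within the scatter). For compound 3, the estimated value is 1800 nM, with an expected range from 700 nM to 4500 nM.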

Compound 3, half-maximal inhibitory concentration: 2400 nM
Estimate against measurement, compound 3: 1.3-fold (0.12 log units) below; measured number inside the range.
By their numbers in this assay, from the lowest: compound 1; then compounds 2 and 3 (each within the scatter of the next).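

In this assay, chloro in place of fluoro on an aromatic carbon, ortho to a large group, gives a 1.1-fold higher number from compound 2 to compound 3 (0.04 log units; within the scatter) and so leaves the read-out unchanged within the scatter, which shows that this position does not separate these two halogens here. With the 2-chlorophenyl held constant, the change of hydroxy to 2-aminophenyl on the amide-type nitrogen can now be read for the first time, and in the listed direction it appears as a 2.7-fold higher number from compound 1 to compound 3 (0.43 log units; beyond the scatter), a modest step beyond the scatter. Nothing available explains either step.

As far as these compounds go, what a bromo, a methyl or a methoxy at this position would give remains open. So does the question of whether the step between hydroxy and 2-aminophenyl keeps its size when a 2-fluorophenyl is present instead of the 2-chlorophenyl.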